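A Methyl-to-Ethyl Swap on the Phenyl Group

A few compounds are considered here, and "the series" means these few. Any claim that something is new, unique, unknown or untested is made for them only; others in the source may bear on it.

In a functional assay on MDA-MB-231 cells (Homo sapiens) for inhibition, read by CCK-8 assay, with a stated time of 48 h (a higher number here means a weaker inhibitor of growth, a lower number a stronger inhibitor of growth), compound 3 (`Cc1cccc(Nc2nc(Nc3ccc(N4CCN(C)CC4)cn3)ncc2Cl)c1`) gives 5270 nM and compound 2 (`Cc1ccc(Nc2nc(Nc3ccc(N4CCN(C)CC4)cn3)ncc2Cl)cc1`) gives 4030 nM as its value. These two sit together, since the step is a 1.3-fold higher number from compound 2 to compound 3 (0.12 log units; within the scatter) and comes from 3-methylphenyl in place of 4-methylphenyl. Compound 1 (`CN1CCN(c2ccc(Nc3ncc(Cl)c(NCc4ccc(C(F)(F)F)cc4)n3)nc2)CC1`) stands apart at 19100 nM on the same scale.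

Compound 4 (`CCc1ccc(Nc2nc(Nc3ccc(N4CCN(C)CC4)cn3)ncc2Cl)cc1`) differs from compound 3 by 4-ethylphenyl in place of 3-methylphenyl on a nitrogen on an aromatic ring and carries 4-ethylphenyl in place of 3-methylphenyl on a nitrogen on an aromatic ring. Among the compounds with values here, no measured compound carries an ethyl group, so the closest guide is the small step between the two methylphenyl compounds. The larger steps, a 4.7-fold lower number from compound 1 to compound 2 (0.68 log units; beyond the scatter) and a 3.6-fold lower number from compound 1 to compound 3 (0.56 log units; beyond the scatter) in size, each replace the 4-(trifluoromethyl)benzyl group, a much bigger change than this one.

The estimated step is a 1.2-fold lower number from compound 3 to compound 4 (0.09 log units; within the scatter) and so no real shift is expected. Compound 4 is expected at about 4300 nM within an estimated range of 1900 nM to 9500 nM in this measurement.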

Compound 4, concentration for 50% growth inhibition: 5560 nM
Estimate against measurement, compound 4: 1.3-fold (0.11 log units) below, and the stated range covers the measured number.
By their numbers in this assay, from the lowest: compounds 2, 3 and 4 (each within the scatter of the next); then compound 1.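

Extending the methyl of compound 2 to an ethyl leaves the reading in this assay unchanged within the scatter (a 1.4-fold higher number from compound 2 to compound 4 (0.14 log units; within the scatter)), so this position tolerates one added carbon on the 4-substituent. The comparison with the 3-methylphenyl compound points the same way (a 1.1-fold higher number from compound 3 to compound 4 (0.02 log units; within the scatter)), while the 4-(trifluoromethyl)benzyl compound stays clearly apart (a 3.4-fold lower number from compound 1 to compound 4 (0.54 log units; beyond the scatter)), which places compounds 2, 3 and 4 together as one group. No supporting measurement is available to explain this pattern.

A longer chain such as butyl, or an amine or carboxylic acid on the phenyl ring, might still move the number. Compound 1 also cannot show whether its higher number belongs to the trifluoromethyl group or to the benzyl link, and an unsubstituted benzyl group would separate the two.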